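Vero cytotoxicity in a biaryl-pyridine carbinol series, next step

A few compounds are considered here, and "the series" means these few. Any claim that something is new, unique, unknown or untested is made for them only; others in the source may bear on it.

Measured so far:
- compound 1 `COc1nc(-c2ccc(OC(F)(F)F)cc2)ccc1[C@@H](c1ccccc1)[C@@](O)(CCN(C)C)c1cccc2ccccc12`: in a toxicity assay on Vero cells (Chlorocebus sabaeus) for cytotoxicity (a lower number here means that less compound is tolerated, a higher number that more compound is tolerated), compound 1 gives > 50 ug/mL, a limit of the assay
- compound 2 `COc1nc(-c2ccc(Cl)c(F)c2)ccc1[C@@H](c1ccccc1)[C@@](O)(CCN(C)C)c1cccc2ccccc12`: in this assay compound 2 gives > 50 ug/mL, a limit of the assay

Compound 2 stands at the assay limit, with no number read for it. Among the measured compounds shown here, the one measured step, a step that the two limits leave unreadable from compound 1 to compound 2, is therefore of unreadable size, and the only evidence on the series is the limit of > 50 ug/mL in this assay, at which 2 of the 2 values shown sit.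

Compound 3 `COc1nc(-c2ccc(C#N)cc2)ccc1[C@@H](c1ccccc1)[C@@](O)(CCN(C)C)c1cccc2ccccc12` is the next member. The change is 4-cyanophenyl in place of 4-chloro-3-fluorophenyl on an aromatic carbon, with the difference confined to the pendant aryl group on the shared core.

For the measured compounds named here, no measured step gives a readable size to compare with, so no step beyond the scatter is expected in this assay. Compound 3 is expected to sit again at the limit, estimated at 50 ug/mL with a range of 30 ug/mL to 100 ug/mL. The estimated step is a number no higher from compound 2 to compound 3 (the limit leaves the size open).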

Compound 3, half-maximal cytotoxic concentration: > 50 ug/mL
Compound 3 was reported as a limit; the forecaster's own chance of this, stated with the estimate: 80%; the middle value sits exactly at the limit.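

No step among compound 1, compound 2 and compound 3 can be read, and the evidence on the series stays as it was: the limit of > 50 ug/mL in this assay, at which 3 of the 3 values shown sit.

The compounds shown leave open whether any of these pendant aryl groups differs from the others in this assay, since none has a readable value.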